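Isopropyl to 4-fluorobenzyl on the amide nitrogen

The source may hold more compounds than are shown below. What is called first, only, known or untested is meant among the compounds shown, and "the series" means these compounds.

Compound 1, `N#Cc1cccc(Oc2ncccc2C(=O)NCc2ccccc2)c1`: 0.1 mg/kg
Compound 2, `CC(C)NC(=O)c1cccnc1Oc1ccc(F)cc1`: 0.001 mg/kg

In a functional assay on the whole organism with Mus musculus as the target (a lower number here means that less compound is needed, a higher number that more compound is needed for the effect), compound 2 gives 0.001 mg/kg, the lowest of the two numbers. For the measured compounds named here, compound 1 gives 0.1 mg/kg in this assay, a higher number beyond the scatter, but it differs from compound 2 in more than one place, so no single step is known. Compound 3, `O=C(NCc1ccc(F)cc1)c1cccnc1Oc1ccc(F)cc1`, is not yet measured. It differs from compound 2 by 4-fluorobenzyl in place of isopropyl on an amide-type nitrogen. The step of a 10-fold higher number from compound 2 to compound 3 (1.00 log units; beyond the scatter) is expected to run towards a higher number, of modest size. The value expected for compound 3 is 0.01 mg/kg, with a range from 0.001 mg/kg to 0.1 mg/kg.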

Compound 3, minimum effective dose: 0.01 mg/kg
For compound 3 middle estimate and measured number coincide at the digits printed, and the stated range covers the measured number.
By their numbers in this assay, from the lowest: compound 2; then compound 3; then compound 1.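

For the compounds shown here, on the amide-type nitrogen, 4-fluorobenzyl in place of isopropyl gives a 10-fold higher number from compound 2 to compound 3 (1.00 log units; beyond the scatter) in this assay, the first single-place step, and shows that this position is sensitive to the change while activity remains measurable at a low dose. Steps involving compound 1 cannot be read, as it differs from the others in more than one place. No measured data on the shared core explain the step. Whether the ring or its fluorine accounts for the step remains open, as does the effect of a cyclopropyl group or a longer alkyl chain on this nitrogen.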